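The source may hold more compounds than are shown below. What is called first, only, known or untested is meant among the compounds shown, and "the series" means these compounds.

Compound 1 `Cn1ncc(Cl)c1-c1cc(C(=O)N[C@@H]2CN[C@H](CCN3CCC(O)CC3)C[C@H]2c2ccc(Cl)c(Cl)c2)oc1Cl`: 13700 nM
Compound 2 `C=CC[C@@H]1C[C@@H](c2ccc(Cl)c(Cl)c2)[C@H](NC(=O)c2cc(-c3c(Cl)cnn3C)c(Cl)o2)CN1`: 780 nM
Compound 3 `CN(C)CC[C@@H]1C[C@@H](c2ccc(Cl)c(Cl)c2)[C@H](NC(=O)c2cc(-c3c(Cl)cnn3C)c(Cl)o2)CN1`: 1710 nM

All three values come from a functional assay on HCT-116 cells (Homo sapiens) for antiproliferative activity, read by sulforhodamine B assay, with a stated time of 72 h; on this read-out lower numbers stand for stronger inhibition and higher numbers for weaker inhibition. Compound 3 stands in the middle of the three, with a 2.2-fold higher number from compound 2 to compound 3 (0.34 log units; beyond the scatter) as its nearest step and an 8.0-fold lower number from compound 1 to compound 3 (0.90 log units; beyond the scatter) as its furthest.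

Compound 4 `COCC[C@@H]1C[C@@H](c2ccc(Cl)c(Cl)c2)[C@H](NC(=O)c2cc(-c3c(Cl)cnn3C)c(Cl)o2)CN1` carries methoxy in place of dimethylamino on a saturated chain carbon, two bonds along the chain from a saturated ring carbon. Among the compounds with values here, no measured step makes this exact change. The closest evidence is the pair of steps above, and an 18-fold lower number from compound 1 to compound 2 (1.24 log units; beyond the scatter) shows that this chain can move the number widely. With compound 2 as the nearest chain lacking dimethylamino, a modest move to a lower number is expected in this assay: a 2.1-fold lower number from compound 3 to compound 4 (0.33 log units; beyond the scatter). For compound 4 the estimated value is 800 nM, with an expected range of 300 nM to 2000 nM.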

Compound 4, half-maximal inhibitory concentration: 470 nM
Beside the measured number, compound 4's estimate is 1.7-fold (0.23 log units) above it; the range from low to high includes it.
By their numbers in this assay, from the lowest: compounds 4 and 2 (each within the scatter of the next); then compound 3; then compound 1.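

In this assay, methoxy in place of dimethylamino gives a 3.6-fold lower number from compound 3 to compound 4 (0.56 log units; beyond the scatter), although the two groups count the same hydrogen-bond donors and acceptors and neither carries a net charge. Methoxymethyl and vinyl at this place cannot be told apart, with a 1.7-fold lower number from compound 2 to compound 4 (0.22 log units; within the scatter). The widest gap in the set is now a 29-fold lower number from compound 1 to compound 4 (1.46 log units; beyond the scatter), where 4-hydroxypiperidin-1-yl is the group that leaves. Nothing measured here explains these steps. On these data alone, whether a carboxylic acid or a longer ether chain at this place would read like methoxy or like dimethylamino remains open.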